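From 3-fluorophenyl to 2,6-difluorophenyl on the ring nitrogen

The source may hold more compounds than are shown below. What is called first, only, known or untested is meant among the compounds shown, and "the series" means these compounds.

Compound 3 `Nc1scc(CN2CCN(c3cccc(F)c3)CC2)c1C(=O)c1cccc(C(F)(F)F)c1` gives -35% in a functional assay on CHO cells with adenosine receptor A1 (Homo sapiens) as the target, read by cAMP accumulation and immunoassay, with a stated time of 6 min, tested at 1 uM; a lower number here means a stronger effect, a higher number a weaker effect of the compound at the concentration tested. That number is the second highest of the three measured: compound 1 `Nc1scc(CN2CCN(c3ccccc3C(F)(F)F)CC2)c1C(=O)c1ccc(Cl)cc1` gives -39% and compound 2 `Nc1scc(CN2CCN(c3ccc(C(F)(F)F)cc3)CC2)c1C(=O)c1cccc(C(F)(F)F)c1` gives -27%, both within the scatter of compound 3. Among the compounds with values here, the only single-point step measured so far, a number 8 percentage points lower from compound 2 to compound 3 (within the scatter), changed the group on the same amine nitrogen in a ring and stayed within the scatter. Compound 4 `Nc1scc(CN2CCN(c3c(F)cccc3F)CC2)c1C(=O)c1cccc(C(F)(F)F)c1` differs from compound 3 by 2,6-difluorophenyl in place of 3-fluorophenyl on an amine nitrogen in a ring. Because a number 8 percentage points lower from compound 2 to compound 3 (within the scatter) stayed within the scatter, the expected step is small, no change at the digits printed from compound 3 to compound 4 (within the scatter), with no clear direction. Compound 4 is therefore estimated to give -35% in this assay, within a range from -50% to -20%.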

Compound 4, a percentage reported as activity, at one concentration (the size of the read-out at that concentration, not a potency): 1.3%
Beside the measured number, compound 4's estimate is 36.3 percentage points below it; the whole stated range lies below it.
By their numbers in this assay, from the lowest: compounds 1, 3 and 2 (each within the scatter of the next, the first and the last beyond it); then compound 4.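

The group on this amine nitrogen in a ring can move the read-out in this assay after all. 2,6-Difluorophenyl in place of 3-fluorophenyl gives a number 36.3 percentage points higher from compound 3 to compound 4 (beyond the scatter) and in place of 4-(trifluoromethyl)phenyl it gives a number 28.3 percentage points higher from compound 2 to compound 4 (beyond the scatter) in contrast to the earlier step, which stayed within the scatter. This change alters both the count and the placing of fluorine at once, and the two effects cannot be told apart here.

On these data alone, whether a plain phenyl or a methoxyphenyl on this nitrogen would read like compound 3 or like compound 4 stays open. No measurement shown explains this jump.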